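Moving the trifluoromethyl group on the pyridine of compound 1

The source may hold more compounds than are shown below. What is called first, only, known or untested is meant among the compounds shown, and "the series" means these compounds.

Compound 1, `O=C(c1cc(Cl)ccc1-c1ncccn1)N1CC2(CC2)C[C@H]1CNc1cc(C(F)(F)F)ccn1`, is tested in a functional assay on HEK293 cells for antagonist activity at Orexin receptor type 2 (Homo sapiens), read by FLIPR and calcium flux (on this read-out higher numbers stand for higher potency (the scale is a negative logarithm) and lower numbers for lower potency), where compound 1 gives 7.1. Of the two numbers available, this is the lower one. For the measured compounds named here, compound 2, `Cc1ccc(-c2ncccn2)c(C(=O)N2CC3(CC3)C[C@H]2CNc2cc(C(F)(F)F)ccn2)c1`, gives 7.8 in this assay, and the step of a number 0.70 log units higher from compound 1 to compound 2 (beyond the scatter) is the only measured single change in the set. Compound 3, `Cc1ccc(-n2nccn2)c(C(=O)N2CCC3(CC3)C[C@H]2CNc2ccc(Cl)cn2)c1`, differs from compound 1 in several places at once. Going by the values given here, for compound 3 this assay reports only a limit, < 5, and it is the one value of the three that sits at such a limit (the limit of < 5 in this assay, at which 1 of the 3 values shown sits).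

Compound 4, `O=C(c1cc(Cl)ccc1-c1ncccn1)N1CC2(CC2)C[C@H]1CNc1ccc(C(F)(F)F)cn1`, is not yet measured. It differs from compound 1 by 5-(trifluoromethyl)pyridin-2-yl in place of 4-(trifluoromethyl)pyridin-2-yl on an amine nitrogen. Among the compounds with values here, no measured step in this set changes that part of the molecule, so the size and direction of the effect cannot be read from the data. The closest measured step concerns a change elsewhere in the molecule and is modest. A step of a number 0.30 log units lower from compound 1 to compound 4 (within the scatter) is therefore expected, within or near the scatter. Compound 4 is estimated at 6.8, with a range from 6 to 7.6.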

Compound 4, negative logarithm of the antagonist equilibrium constant: 7.2
For compound 4 the middle estimate is 0.40 log units below the measured one; measured number inside the range.
By their numbers in this assay, from the lowest: compounds 1 and 4 (each within the scatter of the next); then compound 2. At a limit, below all of these: compound 3.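

In this assay, putting 5-(trifluoromethyl)pyridin-2-yl in place of 4-(trifluoromethyl)pyridin-2-yl on the amine nitrogen gives a number 0.10 log units higher from compound 1 to compound 4 (within the scatter) and so leaves the number effectively unchanged. For the compounds shown here, this is the first measured change to this part of the molecule, as the only earlier step, a number 0.70 log units higher from compound 1 to compound 2 (beyond the scatter), comes from swapping chloro for methyl elsewhere on an aromatic carbon. These two trifluoromethyl pyridines, which have the same atoms joined differently, cannot be told apart on this read-out, and nothing measured here bears on why.

From the compounds shown here alone, it remains open whether a different group in place of trifluoromethyl on this pyridine, such as a nitrile or a methoxy group, would also leave the number unchanged. Going by these compounds, it is also open whether methyl in place of chloro would bring a similar gain on the core of compound 4.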